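This account rests on a few compounds, and the source may have more. Where it says the series, first, only, none or still open, it means among the compounds named here.

In a functional assay on ECa-109 cells for inhibition, with ECa-109 cell line (Homo sapiens) as the target, read by sulforhodamine B assay (on this read-out lower numbers stand for stronger inhibition and higher numbers for weaker inhibition), compound 3 `O=C1C(N2CCCC2)=CC(=O)c2c1nc1n2[C@H]2OC[C@@H](O)[C@H]2OC1` gives > 16000 nM, a limit and not a number. Compound 1 `Cc1ccc(NC2=CC(=O)c3c(nc4n3[C@H]3OC[C@@H](O)[C@H]3OC4)C2=O)cc1` gives > 4000 nM, also a limit. Compound 2 `COc1ccccc1NC1=CC(=O)c2c(nc3n2[C@H]2OC[C@@H](O)[C@H]2OC3)C1=O` gives > 4000 nM, again a limit. Compound 4 `COc1cccc(NC2=CC(=O)c3c(nc4n3[C@H]3OC[C@@H](O)[C@H]3OC4)C2=O)c1` differs from compound 3 by (3-methoxyphenyl)amino in place of pyrrolidin-1-yl on a double-bonded ring carbon, with (3-methoxyphenyl)amino in place of pyrrolidin-1-yl on a double-bonded ring carbon. Within the data shown here, two measured steps bear on this change, run the opposite way, and give no usable size: a step that the two limits leave unreadable from compound 1 to compound 3 and a step that the two limits leave unreadable from compound 2 to compound 3. Only a modest move toward lower numbers in this assay is therefore expected, and the expected step is an at least 2.6-fold lower number from compound 3 to compound 4 (0.42 log units; beyond the scatter). The estimate for compound 4 is 6000 nM, with an expected range of 2000 nM to 16000 nM.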

Compound 4, half-maximal inhibitory concentration: 3340 nM
Estimate against measurement, compound 4: 1.8-fold (0.25 log units) above, within the range that was stated.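

Compound 4 gives the first number rather than a limit in this assay on this double-bonded ring carbon, and (3-methoxyphenyl)amino in place of pyrrolidin-1-yl gives an at least 4.7-fold lower number from compound 3 to compound 4 (0.68 log units; beyond the scatter). Against the other arylamines, the change gives an at least 1.1-fold lower number from compound 2 to compound 4 (0.07 log units; that floor lies within the scatter) and an at least 1.1-fold lower number from compound 1 to compound 4 (0.07 log units; that floor lies within the scatter); both floors lie within the scatter, so no order among the three aryl groups can be claimed. The steps among compound 1, compound 2 and compound 3 cannot be read.

On these data alone, how far the aryl substituent itself matters stays open. As far as these compounds go, whether morpholin-4-yl or benzylamino on this carbon would give a readable number also stays open.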